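Hydroxy on the Amine Nitrogen of a Diol Chain

The source may report more compounds than this note shows. Statements on the series, on what has been measured and on what is new or still open speak of the compounds shown alone.

Compound 1 `CC(C)(CO)CCCSCCCC(C)(C)CO` carries a sulfur-linked chain and in a functional assay on cells (Hepatocyte, Rattus norvegicus, strain Sprague-Dawley) for inhibition (a lower number here means a stronger inhibitor, a higher number a weaker inhibitor), compound 1 gives 15000 nM. Compound 2 `CC(C)(CO)CCCCNCCCCC(C)(C)CO` joins the same two ends through an amine instead, and in this assay compound 2 is reported as "not active" (no number reported), so no single number places it. Compound 3 `CC(C)(CO)CCCCN(O)CCCCC(C)(C)CO` differs from compound 2 by hydroxy in place of hydrogen on an amine nitrogen. For the measured compounds named here, with no measured step to lean on, only a modest gain at best is expected for compound 3, and in this assay compound 3 is estimated at 20000 nM, within a range of 4000 nM to 100000 nM.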

Compound 3, half-maximal inhibitory concentration: 63000 nM
For compound 3 the middle estimate is 3.2-fold (0.50 log units) below the measured one, within the range that was stated.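

For the compounds shown here, compound 2 has no single number, so no step from compound 2 to compound 3 can be read. No measured evidence bears on this result. Going by these compounds, what hydroxy in place of hydrogen on the amine nitrogen does to inhibition stays open.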